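The compounds below may be only part of what the source reports. "The series", "measured", "known", "first", "only" and "open" are said of these compounds alone.

Measured compounds:
compound 1 `COc1ccccc1Oc1ccc2c(NCCCNCc3ccco3)ccnc2c1` — 9.28
compound 2 `CC(C)CCc1ccc2c(NCCCNCc3ccco3)ccnc2c1` — 9.47
compound 3 `COc1cccc(CNCCCNc2ccnc3cc(Oc4ccc(F)cc4)ccc23)c1O` — 9.28

In a physicochemical assay for acid dissociation, compound 3 gives 9.28, the same number as compound 1 at the digits given; compound 2 sits within the scatter of both, so the three values cannot be ordered. Compound 4 `Fc1ccc(Oc2ccc3c(NCCCNCc4ccco4)ccnc3c2)cc1` is the next member: it differs from compound 3 by furan-2-yl in place of 2-hydroxy-3-methoxyphenyl on a saturated chain carbon bound to an amine nitrogen. Going by the values given here, the only measured step, a number 0.19 log units higher from compound 1 to compound 2 (within the scatter), concerns the aromatic ether end and lies within the scatter; no measured step touches the group on the amine. Compounds 1 and 2 already carry the entering furan-2-yl group and give values within the scatter of compound 3. Compound 4 is therefore expected to show a step of a number 0.07 log units higher from compound 3 to compound 4 (within the scatter), nothing beyond the scatter. The estimate for compound 4 is 9.35, with a range from 9.05 to 9.65.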

Compound 4, acid dissociation constant: 9.28
Estimate against measurement, compound 4: 0.07 log units above; measured number inside the range.
By their numbers in this assay, from the lowest: compounds 1, 3, 4 and 2 (each within the scatter of the next).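

In this assay, furan-2-yl in place of 2-hydroxy-3-methoxyphenyl on a saturated chain carbon bound to an amine nitrogen, the first step read at this position, gives no change at the digits printed from compound 3 to compound 4 (within the scatter). The other two steps stay inside the scatter as well: 4-fluorophenyl in place of 2-methoxyphenyl on an oxygen on an aromatic ring gives no change at the digits printed from compound 1 to compound 4 (within the scatter), and 4-fluorophenoxy in place of isopentyl on an aromatic carbon gives a number 0.19 log units lower from compound 2 to compound 4 (within the scatter). No evidence beyond these numbers bears on this result.

Still open, going by these compounds, is whether a carboxylic acid or a second amine in place of furan-2-yl at this position would move the number beyond the scatter. The same question stands for a longer chain.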